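Removing the Carboxymethyl Group from Compound 1

The compounds below may be only part of what the source reports. "The series", "measured", "known", "first", "only" and "open" are said of these compounds alone.

Compound 1 `O=C(O)CNc1cccc(CNc2cc(C(F)(F)F)cc3[nH]ncc23)c1` was tested in an assay for inhibition of Indoleamine 2,3-dioxygenase 1 (Homo sapiens), with stated times of 10 min and 60 min; on this read-out lower numbers stand for stronger inhibition and higher numbers for weaker inhibition. In this assay compound 1 gives only a limit, > 100000 nM, and no number. That value is the limit of > 100000 nM in this assay, at which 1 of the 2 values shown sits, so compound 1 stands at the weak end of what the numbers show. Compound 2 `O=[N+]([O-])c1ccc(O)cc1CNc1cc(Br)cc2[nH]ncc12`, measured in this assay, gives 910 nM. Among the compounds with values here, no step between compound 1 and compound 2 has been computed, so nothing beyond the two values themselves can be said of that pair. Compound 3 `Nc1cccc(CNc2cc(C(F)(F)F)cc3[nH]ncc23)c1` has not yet been measured. It differs from compound 1 by hydrogen in place of carboxymethyl on a nitrogen on an aromatic ring. Within the data shown here, no measured step of this kind exists here, so the expectation rests on the limit alone: the expected step of an at least 3.3-fold lower number from compound 1 to compound 3 (0.52 log units; beyond the scatter) points toward stronger inhibition, beyond the scatter. Compound 3 is accordingly estimated at 30000 nM, within 3000 nM to 100000 nM.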

Compound 3, half-maximal inhibitory concentration: > 100000 nM
Compound 3 ended at the assay's limit (the forecaster's own chance of this, stated with the estimate: 45%); at least 3.3-fold (0.52 log units) between middle value and limit.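

In this assay compound 1 and compound 3 both give only a limit, so no step can be read between them. The compounds shown leave open whether hydrogen in place of carboxymethyl on this nitrogen changes inhibition at all.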